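Anilide to Benzylamide: One Step in a Cytotoxicity Series

The source may report more compounds than this note shows. Statements on the series, on what has been measured and on what is new or still open speak of the compounds shown alone.

Compound 1 `CCSC(=S)SCC(=O)c1ccc(CN(C)C(C)=O)cc1`: 21500 nM
Compound 2 `CCSC(=S)SCC(=O)c1ccc(C(=O)Nc2ccccc2)cc1`: 25800 nM

In a functional assay on HeLa cells (Homo sapiens) for cytotoxicity, read by resazurin assay, with a stated time of 72 h (on this read-out higher numbers stand for weaker inhibition and lower numbers for stronger inhibition), compound 2 gives 25800 nM, which lies within the scatter of compound 1 at 21500 nM. Compound 3 `CCSC(=S)SCC(=O)c1ccc(C(=O)NCc2ccccc2)cc1` has not yet been measured. It differs from compound 2 by one change: benzyl in place of phenyl on an amide-type nitrogen. Going by the values given here, no measured step shows what such a change does, so no shift beyond the scatter is expected in this assay. The estimated 1.2-fold lower number from compound 2 to compound 3 (0.07 log units; within the scatter) is accordingly small. For compound 3, the expected value is 22000 nM, with a range of 9000 nM to 50000 nM.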

Compound 3, half-maximal inhibitory concentration: 23900 nM
For compound 3 the middle estimate is 1.1-fold (0.04 log units) below the measured one; the range from low to high includes it.
By their numbers in this assay, from the lowest: compounds 1, 3 and 2 (each within the scatter of the next).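

In this assay, benzyl in place of phenyl on an amide-type nitrogen gives a 1.1-fold lower number from compound 2 to compound 3 (0.03 log units; within the scatter). Going by these compounds alone, this is the first measured step at this place, and it shows that going from anilino to benzylamino leaves the number within the scatter. Nothing in the data shown explains this result.

The compounds shown leave open what a phenethyl chain, a cyclohexyl group or a carboxylic acid would do on this nitrogen. They also leave open whether any change at this place can move the number beyond the scatter.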